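Three oximes and a thiazole analogue in a cytotoxicity screen

A few compounds are considered here, and "the series" means these few. Any claim that something is new, unique, unknown or untested is made for them only; others in the source may bear on it.

Compound 1, `O/N=C/c1nc2ccccc2s1`: "not determined" (no result reported)
Compound 2, `C/C(=N\O)c1nc2ccccc2s1`: > 100000 nM
Compound 3, `Cc1nnc(/C(=N\O)c2nc3ccccc3s2)o1`: "not determined" (no result reported)

The three measured compounds share a core and differ only in the group attached to the oxime carbon. In an ADME assay on CHO cells (Cricetulus griseus) for cytotoxicity (on this read-out higher numbers stand for weaker inhibition and lower numbers for stronger inhibition), compound 1 and compound 3 have no result at all. Compound 2 gives > 100000 nM in this assay, which is a limit of the assay and not a number. So compound 3 stands without a figure of its own; of the three entries shown, one further is a limit and one further carries no number, and the limit is the limit of > 100000 nM in this assay, at which 1 of the 3 values shown sits.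

The step from compound 3 to the unmeasured compound 4, `Cc1cnc(/C(=N\O)c2nc3ccccc3s2)s1`, is 5-methyl-1,3-thiazol-2-yl in place of 5-methyl-1,3,4-oxadiazol-2-yl on a carbon with a double bond to nitrogen. For the measured compounds named here, no measured step exists that would show how this kind of change moves the read-out in this assay. With only a limit from compound 2 as a guide, the expectation is for no step beyond the scatter, and for compound 4 to land in the same weakly cytotoxic region. Compound 4 is therefore estimated to give 100000 nM in this assay, within a range from 30000 nM to 300000 nM, with a real chance that only a limit is reported.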

Compound 4, half-maximal inhibitory concentration: 29000 nM
The estimate for compound 4 lay 3.4-fold (0.54 log units) above the measured number, outside the stated range (below it).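

In this assay compound 2 gives > 100000 nM, a limit of the assay and not a number. In this assay compound 4 gives 29000 nM, the only single number among the compounds shown, so a change of group on this carbon with a double bond to nitrogen can bring the read-out into a range where a figure can be given. With 5-methyl-1,3-thiazol-2-yl in place of methyl, the data show an at least 3.4-fold lower number from compound 2 to compound 4 (0.53 log units; beyond the scatter), a real move towards stronger inhibition, though this rests on a single pair of compounds and is no general rule.

From the compounds shown here alone, whether another group at this place, such as an amine, a carboxylic acid or a longer chain, would shift the number further, and in which direction, stays open. Going by these compounds, compound 3 has no number, so the swap of its 5-methyl-1,3,4-oxadiazol-2-yl for 5-methyl-1,3-thiazol-2-yl cannot be read, and the full size of the step from the methyl compound stays unknown because that step starts from a limit: the limit of > 100000 nM in this assay, at which 1 of the 4 values shown sits.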